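Replacing the imidazolyl group of compound 2

The source may hold more compounds than are shown below. What is called first, only, known or untested is meant among the compounds shown, and "the series" means these compounds.

In a physicochemical assay for solubility, read by LC-MS, in phosphate buffer, with a stated time of 24 h, at pH 7.4 (on this read-out higher numbers stand for higher solubility and lower numbers for lower solubility), compound 1 (`O=C1CCCN1c1cnc(NCc2c(F)ccc3c2CCO3)c2cn[nH]c(=O)c12`) reads < 2000 nM which is a limit of the assay and not a number. Within the data shown here, compound 2 (`CNC(=O)c1ncc(-c2cnc(NCc3c(F)ccc4c3CCO4)c3cn[nH]c(=O)c23)n1C`) gives 5000 nM as the only true number so far. Compound 3 (`CN(c1ccn(C)n1)c1cnc(NCc2c(F)ccc3c2CCO3)c2cn[nH]c(=O)c12`) carries methyl(1-methyl-1H-pyrazol-3-yl)amino in place of 1-methyl-2-(methylcarbamoyl)-1H-imidazol-5-yl on an aromatic carbon. Among the measured compounds shown here, the one measured step (an at least 2.5-fold higher number from compound 1 to compound 2 (0.39 log units; beyond the scatter)) introduced that same imidazolyl group, so its removal suggests a partial return toward the lower reading. A modest drop is expected in this assay (a 2.3-fold lower number from compound 2 to compound 3 (0.36 log units; beyond the scatter)). Compound 3 is estimated at 2200 nM (range 700 nM to 6000 nM).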

Compound 3, solubility: 12000 nM
Compound 3: middle estimate off by 5.5-fold (0.74 log units), on the low side; measured number above the stated range.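

In this assay, methyl(1-methyl-1H-pyrazol-3-yl)amino on this aromatic carbon gives a 2.4-fold higher number from compound 2 to compound 3 (0.38 log units; beyond the scatter), so the imidazolyl group of compound 2 is not required for the higher reading. Against 2-oxopyrrolidin-1-yl, the same group gives an at least 6.0-fold higher number from compound 1 to compound 3 (0.77 log units; beyond the scatter). Compound 1 reads < 2000 nM, which is a limit of the assay and not a number.

The compounds shown leave open whether the rise follows the 1-methyl-1H-pyrazol-3-yl ring or its methylated amine link. A plain dimethylamino group or a morpholine on the same aromatic carbon would separate the two.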